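The source may report more compounds than this note shows. Statements on the series, on what has been measured and on what is new or still open speak of the compounds shown alone.

In a functional assay on VCaP cells (Homo sapiens) for antiproliferative activity, read by propidium iodide staining, with a stated time of 96 h (a higher number here means a weaker inhibitor, a lower number a stronger inhibitor), compound 1 `CC(O)(COc1cccc(S(F)(F)(F)(F)F)c1)C(=O)Nc1ccc(S(F)(F)(F)(F)F)cc1` gives 11400 nM, compound 2 `CC(O)(COc1cccc(S(F)(F)(F)(F)F)c1)C(=O)Nc1ccc(C(F)(F)F)cc1` gives 23800 nM and compound 3 `CC(O)(CS(=O)(=O)c1ccccc1OC(F)(F)F)C(=O)Nc1cccc(S(F)(F)(F)(F)F)c1` gives 13900 nM. The values of compound 2 and compound 3 lie within the usual scatter of each other, so these two cannot be ranked. Compound 4 `CC(O)(COc1cccc(C(F)(F)C(F)(F)F)c1)C(=O)Nc1ccc(C(F)(F)F)cc1` keeps the core of compound 2 and alters a single group, with 1,1,2,2,2-pentafluoroethyl entering on an aromatic carbon: a group of 7 heavy atoms (2 carbon, 5 fluorine; no ring) in place of a group of 6 heavy atoms (5 fluorine, 1 sulfur; no ring), on an aromatic carbon. Among the compounds with values here, only one measured step bears on this change, namely a 2.1-fold higher number from compound 1 to compound 2 (0.32 log units; beyond the scatter). That step is modest, just beyond the scatter. It removes the same kind of group as the new change does, but at a different place in the molecule, and the group that replaces it is a different one. It therefore gives only indirect guidance and no firm direction, so no step beyond the scatter is expected in this assay. The estimated change is a 1.1-fold lower number from compound 2 to compound 4 (0.03 log units; within the scatter). For compound 4 the estimated value is 22000 nM, with an expected range from 10000 nM to 45000 nM.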

Compound 4, half-maximal inhibitory concentration: 8100 nM
Estimate against measurement, compound 4: 2.7-fold (0.43 log units) above; measured number outside the range, below it.
By their numbers in this assay, from the lowest: compounds 4, 1, 3 and 2 (each within the scatter of the next, the first and the last beyond it).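

In this assay, putting 1,1,2,2,2-pentafluoroethyl in place of the group of 6 heavy atoms (5 fluorine, 1 sulfur) gives a 2.9-fold lower number from compound 2 to compound 4 (0.47 log units; beyond the scatter) on this aromatic carbon, meta to a large group. Within the data shown here, this is the first measured step at this place, and it shows that the number here responds to the choice of group. The two groups have the same fluorine count, no hydrogen-bond donors or acceptors and no net charge, yet they are not interchangeable here, and nothing measured explains the difference.

One pair cannot show whether a longer chain such as heptafluoropropyl, or a single chlorine atom, would lower the number further at this place. Going by these compounds, whether the same swap gives a similar step on the core of compound 1 also stays open.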